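Replacing 4-(dimethylamino)phenyl with 3,5-dichlorophenyl on a shared core

A few compounds are considered here, and "the series" means these few. Any claim that something is new, unique, unknown or untested is made for them only; others in the source may bear on it.

Of the compounds shown here, three sharing one core have been measured in an ADME assay on A549 cells (Homo sapiens) for cytotoxicity, read by resazurin assay, with a stated time of 48 h; a lower number here means that less compound is tolerated, a higher number that more compound is tolerated. Compound 1 `O=C(Nc1ccc(NCc2ccc(Br)cc2)cc1Cl)c1cc(Cl)ccc1O`, which carries a bromo group, gives 40900 nM. Compound 2 `O=C(Nc1ccc(NCc2ccc(C(F)(F)F)cc2)cc1Cl)c1cc(Cl)ccc1O`, which carries trifluoromethyl instead, gives 62700 nM. Compound 3 `CN(C)c1ccc(CNc2ccc(NC(=O)c3cc(Cl)ccc3O)c(Cl)c2)cc1`, which carries dimethylamino, gives 24500 nM, the lowest of the three numbers, although only its gap to compound 2 lies beyond the scatter.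

Compound 4 `O=C(Nc1ccc(NCc2cc(Cl)cc(Cl)c2)cc1Cl)c1cc(Cl)ccc1O` has not been measured yet. It has 3,5-dichlorophenyl in place of 4-(dimethylamino)phenyl on a saturated chain carbon bound to a nitrogen on an aromatic ring.

Within the data shown here, no measured step makes exactly this swap, so the nearest evidence is the steps that bring in dimethylamino. The data show a 1.7-fold lower number from compound 1 to compound 3 (0.22 log units; within the scatter) and a 2.6-fold lower number from compound 2 to compound 3 (0.41 log units; beyond the scatter). Read backwards, both suggest that losing dimethylamino raises the number in this assay, by a small to modest amount. The data also show a 1.5-fold higher number from compound 1 to compound 2 (0.19 log units; within the scatter), so the two groups without dimethylamino are not told apart. A small upward step is therefore expected, and it may stay within the scatter. The estimated step is a 1.7-fold higher number from compound 3 to compound 4 (0.23 log units; within the scatter). For compound 4 the estimated value is 42000 nM, with an expected range from 20000 nM to 85000 nM.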

Compound 4, half-maximal cytotoxic concentration: 13300 nM
The estimate for compound 4 lay 3.2-fold (0.50 log units) above the measured number, and the stated range ends above it.
By their numbers in this assay, from the lowest: compounds 4, 3, 1 and 2 (each within the scatter of the next, the first and the last beyond it).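

In this assay, the swap for 4-(dimethylamino)phenyl gives a 1.8-fold lower number from compound 3 to compound 4 (0.27 log units; within the scatter), so a group without dimethylamino can sit level with the dimethylamino compound, and the earlier hint that losing dimethylamino raises the number does not hold for this change. The steps of a 3.1-fold lower number from compound 1 to compound 4 (0.49 log units; beyond the scatter) and a 4.7-fold lower number from compound 2 to compound 4 (0.67 log units; beyond the scatter) show something the first three compounds could not: groups without dimethylamino at this place, on a saturated chain carbon bound to a nitrogen on an aromatic ring, can be told apart, whereas bromo and trifluoromethyl alone were not separated. The data offer no measurement that would account for these differences.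

The compounds shown leave open whether the change from 4-bromophenyl to 3,5-dichlorophenyl works through the kind of group or through where its substituents sit on the ring, a question that a plain 4-chlorophenyl or a 3-chlorophenyl group would help to settle. They also leave open how far the number moves with a quite different group at this place, such as a carboxylic acid or a primary amine on the phenyl ring, or with a longer chain in place of the single saturated carbon.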